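Extending an Ester Chain on a Chlorinated Lactone Core

The compounds below may be only part of what the source reports. "The series", "measured", "known", "first", "only" and "open" are said of these compounds alone.

Among the measured compounds shown here, compound 2 `C=C1/C=C/[C@H](OC(C)=O)[C@@]2(C)[C@@H](OC(C)=O)C[C@@H](OC(C)=O)[C@]3(CO3)[C@@H]2[C@H](OC(C)=O)[C@]2(O)[C@@H](C)C(=O)O[C@H]2[C@H]1Cl` is one of two compounds measured in a functional assay on MG-63 cells (Homo sapiens) for inhibition, read by MTT assay; a lower number here means a stronger inhibitor, a higher number a weaker inhibitor. In this assay compound 2 gives 54000 nM, and compound 1 `C=C1/C=C/[C@H](OC(C)=O)[C@@]2(C)[C@@H](OC(C)=O)[C@@H](OC(C)=O)[C@@H](OC(C)=O)[C@]3(CO3)[C@@H]2[C@H](OC(C)=O)[C@]2(O)[C@@H](C)C(=O)O[C@H]2[C@H]1Cl` gives 38400 nM; the two numbers lie within the scatter of each other, so neither can be called the stronger. For the measured compounds named here, the only measured step, a 1.4-fold higher number from compound 1 to compound 2 (0.15 log units; within the scatter), concerns a different change from the one considered here. Compound 3 `C=C1/C=C/[C@H](OC(C)=O)[C@@]2(C)[C@@H](OC(C)=O)C[C@@H](OC(=O)CC(C)C)[C@]3(CO3)[C@@H]2[C@H](OC(C)=O)[C@]2(O)[C@@H](C)C(=O)O[C@H]2[C@H]1Cl` differs from compound 2 in one place: isopropyl in place of hydrogen on a saturated chain carbon bound to a carbonyl carbon. Going by the values given here, no measured step shares this change, so nothing in the numbers points to a move in either direction. With only that to go on, the number expected for compound 3 in this assay is 54000 nM, with a likely range from 18000 nM to 160000 nM. The step this estimate means, no change at the digits printed from compound 2 to compound 3 (within the scatter), is expected to stay within the usual scatter.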

Compound 3, half-maximal inhibitory concentration: 25000 nM
For compound 3 the middle estimate is 2.2-fold (0.33 log units) above the measured one; low and high end bracket the measured number.
By their numbers in this assay, from the lowest: compounds 3, 1 and 2 (each within the scatter of the next, the first and the last beyond it).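

In this assay, the change of acetoxy to (isobutylcarbonyl)oxy gives a 2.2-fold lower number from compound 2 to compound 3 (0.33 log units; beyond the scatter), a modest step but the first here to go beyond the usual scatter. It shows that this ester position responds to a change in the chain, and that isopropyl in place of hydrogen on the saturated chain carbon bound to a carbonyl carbon does not cost activity in this cell assay. No available evidence accounts for the shift.

A single step cannot separate the effect of the chain's length from that of its branched end, which a straight butyl chain or a longer chain at the same ester could do. On these data alone, whether an amine at the chain end would be accepted, and whether the other acetoxy groups on the shared core respond to the same change, stays open.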